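This account rests on a few compounds, and the source may have more. Where it says the series, first, only, none or still open, it means among the compounds named here.

Three compounds share a chloro-substituted benzylamide bearing a tetrazole and a hydroxy-acyl side chain, and differ in the ring that joins them. Compound 1 `CC(C)(C)C[C@@H](O)C(=O)N1[C@@H]2C[C@@H]2C[C@H]1C(=O)NCc1cc(Cl)ccc1-n1cnnn1` gives 520 nM in a functional assay on a cell-free system (plasma, Homo sapiens), with a stated time of 3 min; on this read-out higher numbers stand for weaker inhibition and lower numbers for stronger inhibition. Compound 2 `Cc1cccc([C@@H](O)C(=O)N2N=CC[C@H]2C(=O)NCc2cc(Cl)ccc2-n2cnnn2)c1` gives 830 nM in this assay, and compound 3 `CC(C)(C)OC[C@@H](O)C(=O)N1[C@H](C(=O)NCc2cc(Cl)ccc2-n2cnnn2)C[C@@H]2C[C@@H]21` gives 500 nM in this assay. On paper compound 2 carries the largest number of the three, yet its gaps to compound 1 and to compound 3 both lie within the usual scatter, so the three stand together as a group of similar inhibitors.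

Compound 4 `CC(C)(C)OC[C@@H](O)C(=O)N1N=CC[C@H]1C(=O)NCc1cc(Cl)ccc1-n1cnnn1` keeps the core of compound 2 and changes only the side chain: (tert-butoxy)methyl in place of 3-methylphenyl on a saturated chain carbon bound to a carbonyl carbon and an oxygen on a saturated carbon. Compound 3 carries the same (tert-butoxy)methyl chain on the core of compound 1, and compound 3 and compound 1 stand together, so this chain has not by itself moved the number. No step beyond the scatter is expected in this assay from compound 2 to compound 4. Compound 4 is therefore estimated at 600 nM in this assay, with a range from 300 nM to 1200 nM, which means an expected step of a 1.4-fold lower number from compound 2 to compound 4 (0.14 log units; within the scatter).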

Compound 4, half-maximal inhibitory concentration: 750 nM
Compound 4: middle estimate off by 1.3-fold (0.10 log units), on the low side; the measured number falls inside the stated range.
By their numbers in this assay, from the lowest: compounds 3, 1, 4 and 2 (each within the scatter of the next).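

In this assay, exchanging 3-methylphenyl for (tert-butoxy)methyl on a saturated chain carbon bound to a carbonyl carbon and an oxygen on a saturated carbon gives a 1.1-fold lower number from compound 2 to compound 4 (0.04 log units; within the scatter). Among these compounds, this pair is the first to compare the two groups on one shared core, and it shows that a side chain with a six-membered aromatic ring of carbon only and a ring-free chain with a hydrogen-bond acceptor stand together here. No measurement bears on why the two groups stand together.

The compounds shown leave open how an amine or a carboxylic acid in this place would read in this assay. They also leave open whether 3-methylphenyl on the core of compound 1 would stand with compound 1 and compound 3.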